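From Methoxy(methyl)amino to Ethoxy on a Nucleoside Urea

This account rests on a few compounds, and the source may have more. Where it says the series, first, only, none or still open, it means among the compounds named here.

Compound 2 `CNC(=O)NC[C@H]1O[C@@H](n2cnc3c(NC(=O)Nc4ccccc4)ncnc32)[C@H](O[Si](C)(C)C(C)(C)C)[C@@H]1CC(=O)N(C)OC` was examined in a functional assay on NCI-H322M cells (Homo sapiens) for antiproliferative activity; on this read-out lower numbers stand for stronger inhibition of growth and higher numbers for weaker inhibition of growth. In this assay compound 2 gives > 100 nM, which is a limit of the assay and not a number. This reading sits at the limit of > 100 nM in this assay, at which 1 of the 2 values shown sits. Compound 1 `CCOC(=O)C[C@H]1[C@@H](O[Si](C)(C)C(C)(C)C)[C@H](n2cnc3c(NC(=O)Nc4ccccc4)ncnc32)O[C@@H]1COC(=O)NC` shares the ethoxycarbonyl group but differs elsewhere in the molecule; in this assay compound 1 gives 31.7 nM. Compound 3 `CCOC(=O)C[C@H]1[C@@H](O[Si](C)(C)C(C)(C)C)[C@H](n2cnc3c(NC(=O)Nc4ccccc4)ncnc32)O[C@@H]1CNC(=O)NC` has not yet been measured. It differs from compound 2 in a single place: ethoxy in place of methoxy(methyl)amino on a carbonyl carbon. Going by the values given here, no measured pair shows this change on its own, so the size of the step can only be estimated. The step of an at least 2.5-fold lower number from compound 2 to compound 3 (0.39 log units; beyond the scatter) is expected to move toward stronger growth inhibition, beyond the usual scatter, because compound 1 carrying the same ethoxycarbonyl group gives 31.7 nM. For compound 3 the expected value is 40 nM, with a likely range from 15 nM to 120 nM.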

Compound 3, concentration for 50% growth inhibition: > 100 nM
Compound 3 ended at the assay's limit; the forecaster's own chance of this, stated with the estimate: 20%; middle value at least 2.5-fold (0.39 log units) away from the limit.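

With ethoxy in place of methoxy(methyl)amino on the carbonyl carbon, compound 3 also ends at a limit of this assay and not at a number, so the step from compound 2 cannot be read: the limit of > 100 nM in this assay, at which 2 of the 3 values shown sit.

The ethoxycarbonyl group alone therefore does not secure growth inhibition. With (methylcarbamoyl)amino in place of (methylcarbamoyl)oxy on a saturated chain carbon bound to a saturated ring carbon, the read-out shows an at least 3.1-fold higher number from compound 1 to compound 3 (0.49 log units; beyond the scatter), so this second place is where a single change is shown to weaken growth inhibition.

Still open, as far as these compounds go, is whether methoxy(methyl)amino on the carbonyl carbon would keep the growth inhibition of compound 1 when (methylcarbamoyl)oxy is present. Also open, from the compounds shown here alone, is whether an amine or a carboxylic acid at that carbonyl would give a readable number alongside (methylcarbamoyl)amino.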